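A Ring Methyl Moved: Growth Inhibition on A-375 Cells

The source may report more compounds than this note shows. Statements on the series, on what has been measured and on what is new or still open speak of the compounds shown alone.

Measured compounds:
compound 1, `N/C(=N\NC(=S)N1CCCCC1)c1ccccn1`, in a functional assay on A-375 cells (Homo sapiens) for cytotoxicity, read by MTT assay, with a stated time of 72 h, tested at 30 uM (on this read-out higher numbers stand for more inhibition of growth at the one concentration tested and lower numbers for less inhibition of growth), compound 1 gives 87%
compound 3, `N/C(=N\NC(=S)N1CCCC1)c1ccccn1`, compound 3 gives 86%
compound 2, `Cc1cccc(/C(N)=N/NC(=S)N2CCCC2)n1`, compound 2 gives 60.8%

Compounds 1 and 3 share everything but the group on the thiocarbonyl carbon: piperidin-1-yl in place of pyrrolidin-1-yl on a thiocarbonyl carbon. That exchange made a step of a number 1 percentage points lower from compound 1 to compound 3 (within the scatter), so the two cores behave alike here. The methyl, however, mattered: methyl in place of hydrogen on an aromatic carbon produced a step of a number 25.2 percentage points lower from compound 3 to compound 2 (beyond the scatter), a modest but real loss.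

Compound 4, `Cc1ccnc(/C(N)=N/NC(=S)N2CCCCC2)c1`, has not yet been measured. It carries the same kind of change relative to compound 1: methyl in place of hydrogen on an aromatic carbon. The place is not identical, though. In compound 2 the methyl sits next to the ring nitrogen, whereas in compound 4 it sits opposite the ring nitrogen; both are meta to a large group. Among the compounds with values here, the one measured example of this kind of change is therefore a guide, not a template.

For compound 4 a step of a number 15 percentage points lower from compound 1 to compound 4 (beyond the scatter) is expected, a loss in the direction shown by the step from compound 3 to compound 2 but tempered because the place differs and only one such step, a number 25.2 percentage points lower from compound 3 to compound 2 (beyond the scatter), is available. Compound 4 is thus estimated to show 72%, expected to lie between 50% and 88%.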

Compound 4, percent growth inhibition at one concentration: 80%
The estimate for compound 4 lay 8 percentage points below the measured number; the range from low to high includes it.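

In this assay, methyl in place of hydrogen on an aromatic carbon, here opposite the ring nitrogen, gave a step of a number 7 percentage points lower from compound 1 to compound 4 (within the scatter), so on the core of compound 1 the change left no loss that can be told from the usual scatter. Set beside the earlier step, the same kind of change did not carry over from one core to the other with the same size: the same change on two cores in this assay, a number 25.2 percentage points lower (beyond the scatter) from compound 3 to compound 2 and a number 7 percentage points lower (within the scatter) from compound 1 to compound 4, 18.2 percentage points apart, beyond the scatter of two such steps This does not show what sets the two steps apart, since they differ both in the group on the thiocarbonyl carbon and in the place of the methyl on the ring, and two steps cannot separate these two differences or establish a rule for the series.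

The compounds shown leave open how a methyl would behave on each core if it held the place it has on the other, which is the pairing that would separate ring place from core. They also leave open whether an ethyl, a methoxy group or a chlorine atom at the place opposite the ring nitrogen would follow the methyl of compound 4 or that of compound 2.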